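The source may hold more compounds than are shown below. What is called first, only, known or untested is meant among the compounds shown, and "the series" means these compounds.

Compound 1 `COc1ccc(Sc2nc3cc(N)cc(N)c3nc2-c2ccccc2)cc1`, compound 2 `Nc1cc(N)c2nc(-c3ccccc3)c(Sc3ccc(Cl)c(Cl)c3)nc2c1` and compound 3 `Nc1cc(N)c2nc(-c3ccccc3)c(Oc3ccc(F)cc3)nc2c1` are the measured compounds. In a functional assay on MDA-MB-231 cells (Homo sapiens) for inhibition, read by sulforhodamine B assay, with a stated time of 48 h (on this read-out higher numbers stand for lower toxicity in this test and lower numbers for higher toxicity in this test), compound 1 gives < 100000 nM, a limit of the assay rather than a number. Compound 2 likewise gives only a limit, < 100000 nM. Compound 3 also gives only a limit, < 100000 nM, so where it stands among the three cannot be read. All three sit at the limit of < 100000 nM in this assay, at which 3 of the 3 values shown sit. The steps a step that the two limits leave unreadable from compound 1 to compound 2, a step that the two limits leave unreadable from compound 1 to compound 3 and a step that the two limits leave unreadable from compound 2 to compound 3 are thus of unknown size. Compound 4 `Nc1cc(N)c2nc(-c3ccccc3)c(Sc3ccc(F)cc3)nc2c1` is not yet measured in this assay. It differs from compound 3 by (4-fluorophenyl)sulfanyl in place of 4-fluorophenoxy on an aromatic carbon. Among the measured compounds shown here, no measured step is readable, so no direction beyond the scatter can be expected. The expected step is a step that the limit leaves unreadable from compound 3 to compound 4. Compound 4 is expected to give 50000 nM, between 10000 nM and 100000 nM, most likely again as a limit.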

Compound 4, concentration lethal to 50% of the cells: 83200 nM
The estimate for compound 4 lay 1.7-fold (0.22 log units) below the measured number, and the stated range covers the measured number.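

Compound 4 has a measured number, but compound 1, compound 2 and compound 3 each give only a limit, so no step to compound 4 can be read: the limit of < 100000 nM in this assay, at which 3 of the 4 values shown sit.

As far as these compounds go, how far (4-fluorophenyl)sulfanyl and 4-fluorophenoxy differ on the shared core stays open.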